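Cytotoxicity series: methoxy substitution on the hydrazone aryl ring

This account rests on a few compounds, and the source may have more. Where it says the series, first, only, none or still open, it means among the compounds named here.

Compound 1 `Cn1nnnc1SCC(=O)N/N=C/c1ccccc1` stands highest of the three measured numbers in an ADME assay on NIH3T3 cells (Mus musculus) for cytotoxicity, read by XTT assay, with a stated time of 24 h (on this read-out lower numbers stand for stronger inhibition and higher numbers for weaker inhibition), giving 9700000 nM. Compound 2 `Cn1nnnc1SCC(=O)N/N=C/c1ccc([N+](=O)[O-])cc1` gives 9300000 nM, and a 1.0-fold lower number from compound 1 to compound 2 (0.02 log units; within the scatter). Compound 3 `Cn1nnnc1SCC(=O)N/N=C/c1cccc(Br)c1` gives 316000 nM, and a 31-fold lower number from compound 1 to compound 3 (1.49 log units; beyond the scatter). Compound 4 `COc1ccccc1/C=N/NC(=O)CSc1nnnn1C` differs from compound 1 by methoxy in place of hydrogen on an aromatic carbon. Neither measured step introduces a methoxy, and neither occupies the same place on the ring, so the bearing of both is indirect: the nitro step shows that one substitution left the number unchanged, while the bromo step shows that another lowered it sharply. For the measured compounds named here, with no direct precedent, compound 4 is expected to give a number close to compound 1, with a modest lowering possible, so a 1.9-fold lower number from compound 1 to compound 4 (0.29 log units; within the scatter) is the estimate. For compound 4 the expected value in this assay is 5000000 nM, within a range of 1000000 nM to 15000000 nM.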

Compound 4, half-maximal inhibitory concentration: 3160000 nM
Compound 4: the middle estimate sits 1.6-fold (0.20 log units) above what was measured, within the range that was stated.
By their numbers in this assay, from the lowest: compound 3; then compound 4; then compounds 2 and 1 (each within the scatter of the next).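

In this assay, methoxy on an aromatic carbon, ortho to a large group, gives a 3.1-fold lower number from compound 1 to compound 4 (0.49 log units; beyond the scatter) and so places a real but modest step at this place on the ring. This group carries no net charge and one hydrogen-bond acceptor, and its step is smaller than the large bromo step elsewhere on the ring, a 31-fold lower number from compound 1 to compound 3 (1.49 log units; beyond the scatter). No measured evidence accounts for the methoxy step. As far as these compounds go, whether the step belongs to this place or to methoxy itself stays open. An amine, a carboxylic acid or ethoxy at this place could separate the two.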